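Replacing the Acid Group with a Hydroxypropyl Chain

This account rests on a few compounds, and the source may have more. Where it says the series, first, only, none or still open, it means among the compounds named here.

Of the compounds shown here, three built on one shared core have been tested in an assay on cells for agonist activity at vitamin D3 receptor (Homo sapiens), read by microscopy; on this read-out higher numbers stand for an effect only at larger amounts of compound and lower numbers for an effect already at smaller amounts. Going by the values given here, compound 3 `CCn1c(C(=O)N[C@H](C(=O)O)C(C)C)ccc1C(CC)(CC)c1ccc(C#CC(O)(CC)CC)c(C)c1` is the only one with a number: in this assay compound 3 gives 17.7 nM. Compound 1 `CCn1c(C(=O)NCCC(=O)OC)ccc1C(CC)(CC)c1ccc(C#CC(O)(CC)CC)c(C)c1` reaches only a limit of the assay, giving > 50 nM in this assay. Compound 2 `CCCCC(=O)c1ccc(C(CC)(CC)c2ccc(C#CC(O)(CC)CC)c(C)c2)n1CC` likewise stops at a limit, giving > 50 nM in this assay. Both of these sit at the limit of > 50 nM in this assay, at which 2 of the 3 values shown sit. Going to compound 3 therefore means an at least 2.8-fold lower number from compound 1 to compound 3 (0.45 log units; beyond the scatter) and an at least 2.8-fold lower number from compound 2 to compound 3 (0.45 log units; beyond the scatter), while the step between the two limited compounds, a step that the two limits leave unreadable from compound 1 to compound 2, cannot be sized.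

Compound 4 `CCn1c(C(=O)NCCCO)ccc1C(CC)(CC)c1ccc(C#CC(O)(CC)CC)c(C)c1` has not been measured. It differs from compound 3 by 3-hydroxypropyl in place of 1-carboxy-2-methylpropyl on an amide-type nitrogen. Compound 1, which carries an ester-bearing chain rather than the acid, and compound 2, which carries a plain butyl chain, both stop at the limit, so the two measured steps into compound 3 bear directly on this change: removing the acid-bearing group is expected to send the number back upward by a step of at least modest size. Compound 4 is therefore estimated at 60 nM, within a range of 15 nM to 250 nM, corresponding to an expected step of a 3.4-fold higher number from compound 3 to compound 4 (0.53 log units; beyond the scatter), with a real chance that the assay again reports only a limit.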

Compound 4, half-maximal effective concentration: 137 nM
For compound 4 the middle estimate is 2.3-fold (0.36 log units) below the measured one, and the stated range covers the measured number.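

In this assay, going by these compounds alone, the swap of 1-carboxy-2-methylpropyl for 3-hydroxypropyl on the amide-type nitrogen gives a 7.7-fold higher number from compound 3 to compound 4 (0.89 log units; beyond the scatter) and so puts a size on losing the acid-bearing group, which the earlier compounds could only bound. Compound 4 also shows that a chain without a carboxylic acid can still give a real number at this position, so the acid is helpful here but not required for a readable effect. The steps from compound 1 and from compound 2 to compound 4 cannot be read, because those two compounds stop at a limit: the limit of > 50 nM in this assay, at which 2 of the 4 values shown sit.

The change also removes the branch and the defined stereocentre along with the acid, so the compounds shown do not separate the share of each in the step. A 3-carboxypropyl chain, which keeps the acid on an unbranched chain, or a 1-hydroxy-3-methylbutan-2-yl group, which keeps the branch but swaps the acid for an alcohol, would help to pull these apart, and an amine at the chain end would test another kind of group at the same place.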